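Removing the Methylcarbamoyl Group from an Inactive Biaryl Acid

The source may report more compounds than this note shows. Statements on the series, on what has been measured and on what is new or still open speak of the compounds shown alone.

Measured compounds:
compound 1 `Cc1oc(C(=O)O)cc1COc1ccc(-c2ccoc2)cc1`, > 10000 nM
compound 2 `CNC(=O)c1ccc(-c2ccc(OCc3cc(C(=O)O)oc3C)cc2)cc1`, > 10000 nM

In an assay on cells for displacement of a labelled ligand from prostaglandin E2 receptor EP4 subtype (Homo sapiens), read by scintillation counting (on this read-out lower numbers stand for stronger inhibition and higher numbers for weaker inhibition), compound 2 gives > 10000 nM, which is a limit of the assay and not a number. Compound 1 likewise gives only a limit, > 10000 nM. Among the compounds with values here, compound 2 therefore stands at the limit of > 10000 nM in this assay, at which 2 of the 2 values shown sit, and no measured step between these two compounds is available.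

Compound 3 `Cc1oc(C(=O)O)cc1COc1ccc(-c2ccccc2)cc1` differs from compound 2 by hydrogen in place of methylcarbamoyl on an aromatic carbon. Since compound 2 shows no measurable binding in this assay, the likely outcome for compound 3 is again a limit rather than a number. The step that the limit leaves unreadable from compound 2 to compound 3 is expected to be none beyond the scatter. Compound 3 is estimated at 15000 nM, with a range from 3000 nM to 60000 nM.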

Compound 3, inhibition constant: 420 nM
Estimate against measurement, compound 3: 36-fold (1.55 log units) above; measured number outside the range, below it.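

Compound 3 shows that the outer ring can carry a readable affinity in this series. In this assay, hydrogen in place of methylcarbamoyl, para to a large group, gives an at least 23-fold lower number from compound 2 to compound 3 (1.37 log units; beyond the scatter), so the unsubstituted phenyl binds where the methylcarbamoyl-bearing ring showed no number. The outer ring itself also matters, as phenyl in place of furan-3-yl gives an at least 23-fold lower number from compound 1 to compound 3 (1.37 log units; beyond the scatter), and compound 3 is the only one of the three compounds that leaves the limit: the limit of > 10000 nM in this assay, at which 2 of the 3 values shown sit.

Going by these compounds, both steps start from a limit, so their true size remains unknown. Also open, on these data alone, is whether a methyl, a fluorine, an amine or a carboxylic acid at this same place would keep the binding of compound 3, or whether only hydrogen does.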